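Swapping a hydroxyphenyl for a styryl group in compound 4

A few compounds are considered here, and "the series" means these few. Any claim that something is new, unique, unknown or untested is made for them only; others in the source may bear on it.

Of the compounds shown here, three sharing one core have been measured so far. Compound 1 `N#CC1=C(N)N(c2ccc(S(N)(=O)=O)cc2)C2=C(C(=O)CCC2)C1c1ccccc1` gives 40% in a functional assay on Ehrlich cells (Mus musculus) for antiproliferative activity, read by trypan blue exclusion, with a stated time of 2 h, tested at 50 ug/mL; a higher number here means a stronger effect of the compound at the concentration tested, a lower number a weaker effect. Compound 2 `Cc1ccc(C2C(C#N)=C(N)N(c3ccc(S(N)(=O)=O)cc3)C3=C2C(=O)CCC3)cc1` gives 50% in this assay, and compound 3 `N#CC1=C(N)N(c2ccc(S(N)(=O)=O)cc2)C2=C(C(=O)CCC2)C1c1ccc(O)cc1` gives 100% in this assay. Compound 3 stands highest of the three: its numbers lie well clear of both others, with a number 60 percentage points higher from compound 1 to compound 3 (beyond the scatter) and a number 50 percentage points higher from compound 2 to compound 3 (beyond the scatter), whereas a number 10 percentage points higher from compound 1 to compound 2 (within the scatter). So the hydroxy group on the aromatic ring is what sets compound 3 apart.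

Compound 4 `N#CC1=C(N)N(c2ccc(S(N)(=O)=O)cc2)C2=C(C(=O)CCC2)C1/C=C/c1ccccc1` has not yet been measured. Compared with compound 3, the change is 2-phenylethenyl in place of 4-hydroxyphenyl on a saturated ring carbon. The hydroxy group that carried compound 3 upward is gone, and what enters has no hydrogen-bond donor or acceptor at all, much like the plain phenyl of compound 1 and the methylphenyl of compound 2. The two steps that bear on this, a number 60 percentage points higher from compound 1 to compound 3 (beyond the scatter) and a number 50 percentage points higher from compound 2 to compound 3 (beyond the scatter), both show a large gain when the hydroxy arrives, so its departure is expected to undo that gain. For compound 4 the step of a number 55 percentage points lower from compound 3 to compound 4 (beyond the scatter) is therefore expected, landing near the level of compounds 1 and 2. The estimate for compound 4 is 45%, with a range from 25% to 70%.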

Compound 4, a percentage reported as activity, at one concentration (the size of the read-out at that concentration, not a potency): 40%
Beside the measured number, compound 4's estimate is 5 percentage points above it, and the stated range covers the measured number.
By their numbers in this assay, from the lowest: compounds 1, 4 and 2 (each within the scatter of the next); then compound 3.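

The 2-phenylethenyl group, which brings a double bond outside the aromatic rings to this saturated ring carbon, gives a number 60 percentage points lower from compound 3 to compound 4 (beyond the scatter) in this assay and so does not hold the level of compound 3. Among the groups without a hydroxy, the change counts for little: there is a number 10 percentage points lower from compound 2 to compound 4 (within the scatter) and also no change at the digits printed from compound 1 to compound 4 (within the scatter) in the same read-out, so phenyl, 4-methylphenyl and 2-phenylethenyl cannot be told apart here despite the added double bond. Compound 3 alone stands apart among these four compounds, and it alone carries a hydroxy group, but nothing available explains why this group makes the difference.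

The compounds shown leave open whether a hydroxy placed on the aromatic ring of the 2-phenylethenyl group would bring back the level of compound 3, and whether a methoxy group, an amine or a carboxylic acid could stand in for the hydroxy on the phenyl ring. They also leave open how a saturated 2-phenylethyl group at this carbon would compare with 2-phenylethenyl.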